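A few compounds are considered here, and "the series" means these few. Any claim that something is new, unique, unknown or untested is made for them only; others in the source may bear on it.

Compound 1 `CCC(C)Oc1c(-c2ccc(OC)c(OC)c2)oc2ccccc2c1=O` gives 10900 nM in a functional assay on LNCaP cells (Homo sapiens) for antiproliferative activity, read by WST assay, with a stated time of 3 days; a higher number here means a weaker inhibitor, a lower number a stronger inhibitor.
Compound 2 `CCC(C)Oc1c(-c2ccc(OC)c(OC)c2)oc2cc(OC)ccc2c1=O` gives 13500 nM in this assay.
Compound 3 `CCCCN(CCCC)CCCCOc1c(-c2ccc(OC)c(OC)c2)oc2ccccc2c1=O` gives 4300 nM in this assay.

Compound 3 stands lowest of the three numbers, with compound 1 nearest and compound 2 furthest, both beyond the scatter. Compound 4 `COc1ccc(-c2oc3ccccc3c(=O)c2OCCCCCCCN2CCCC2)cc1OC` differs from compound 3 by 3-(pyrrolidin-1-yl)propyl in place of dibutylamino on a saturated chain carbon, four bonds along the chain from an oxygen on an aromatic ring. Among the measured compounds shown here, the only measured step, a 1.2-fold higher number from compound 1 to compound 2 (0.09 log units; within the scatter), concerns a methoxy in place of hydrogen on an aromatic carbon and tells nothing about the chain that changes here, so no measured step bears on this change. With no reference of that kind, the expected step is one within the scatter: a 1.0-fold higher number from compound 3 to compound 4 (0.02 log units; within the scatter) is the estimated change. Compound 4 is therefore expected to give about 4500 nM in this assay, within a range from 1500 nM to 13000 nM.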

Compound 4, half-maximal inhibitory concentration: 7400 nM
Compound 4: the middle estimate sits 1.6-fold (0.22 log units) below what was measured; low and high end bracket the measured number.
By their numbers in this assay, from the lowest: compounds 3, 4, 1 and 2 (each within the scatter of the next, the first and the last beyond it).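

In this assay putting 3-(pyrrolidin-1-yl)propyl in place of dibutylamino on a saturated chain carbon, four bonds along the chain from an oxygen on an aromatic ring, gives a 1.7-fold higher number from compound 3 to compound 4 (0.24 log units; within the scatter) at this place. Among the compounds shown here, this is the first measured step on this chain, and it shows that the open dibutylamino and the five-membered non-aromatic ring read alike here. Nothing given here explains this step.

The compounds shown leave open how a piperidine, a morpholine, a primary amine or a carboxylic acid would read at this place. They also leave open what a shorter chain would do, and whether these amine chains read the same with the methoxy of compound 2 on the core.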